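Series notes: compound 2 to compound 4 in cytotoxicity

The source may hold more compounds than are shown below. What is called first, only, known or untested is meant among the compounds shown, and "the series" means these compounds.

For the measured compounds named here, in an ADME assay on MT4 cells (Homo sapiens) for cytotoxicity, read by MTT assay, with a stated time of 4 days (on this read-out higher numbers stand for lower toxicity in this test and lower numbers for higher toxicity in this test), compound 2 `C/C(=N\NC(=O)COc1cccc2ccccc12)c1cccc([N+](=O)[O-])c1` gives 12.1 ug/mL, the second highest of the three numbers so far. Compound 1 `CCOc1ccc(/C=N/NC(=O)COc2cccc3ccccc23)cc1O` gives 6.23 ug/mL, which lies within the scatter of compound 2; compound 3 `O=C(COc1cccc2ccccc12)N/N=C/C=C/c1ccccc1` gives 82.7 ug/mL, a gap beyond the scatter. Compound 4 `C/C(=N\NC(=O)COc1cccc2ccccc12)c1ccc([N+](=O)[O-])cc1` is not yet measured in this assay. Relative to compound 2 the change is 4-nitrophenyl in place of 3-nitrophenyl on a carbon with a double bond to nitrogen. Going by the values given here, no step between measured compounds shows what moving a group around a ring does here, and the two compounds hold the same atoms joined differently. On that basis no step beyond the scatter is expected in either direction, and the estimated step from compound 2 to compound 4 is a 1.0-fold lower number from compound 2 to compound 4 (0.00 log units; within the scatter). Compound 4 is therefore estimated at 12 ug/mL, with a range from 5 ug/mL to 30 ug/mL.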

Compound 4, half-maximal cytotoxic concentration: 89.3 ug/mL
Beside the measured number, compound 4's estimate is 7.4-fold (0.87 log units) below it; the measured number lies above the stated range.
By their numbers in this assay, from the lowest: compounds 1 and 2 (each within the scatter of the next); then compounds 3 and 4 (each within the scatter of the next).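

In this assay, for the compounds shown here, 4-nitrophenyl in place of 3-nitrophenyl on a carbon with a double bond to nitrogen gives a 7.4-fold higher number from compound 2 to compound 4 (0.87 log units; beyond the scatter), the first step that can be read and one beyond the scatter. The two groups hold the same atoms, so how they are joined is all that separates these compounds, and the change runs toward lower toxicity in this test. Nothing at hand accounts for the step.

As far as these compounds go, it remains open whether the step belongs to the nitro group alone. A pair such as 3-aminophenyl and 4-aminophenyl at the same place would test that.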